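A chloro group on the phenyl ring of compound 2

A few compounds are considered here, and "the series" means these few. Any claim that something is new, unique, unknown or untested is made for them only; others in the source may bear on it.

In a physicochemical assay for solubility, at pH 7.4 (a lower number here means a less soluble compound, a higher number a more soluble compound), compound 2 (`CN1CCC(C(c2ccccc2)N2CCN(C(=O)CC(c3ccccc3)c3ccccc3)CC2)CC1`) gives 63.6 ug/mL as the highest of three numbers. Compound 1 (`O=C(CC(c1ccccc1)c1ccccc1)N1CCN(C(c2ccccc2)c2ccccc2Cl)CC1`) gives 0.37 ug/mL and compound 3 (`O=C(NC(c1ccccc1)c1ccccc1)N1CCN(C(c2ccccc2)c2ccccc2)CC1`) gives 0.38 ug/mL as two values within the scatter of each other. Compound 4 (`CN1CCC(C(c2ccc(Cl)cc2)N2CCN(C(=O)CC(c3ccccc3)c3ccccc3)CC2)CC1`) has chloro in place of hydrogen on an aromatic carbon, para to a large group, so that phenyl becomes 4-chlorophenyl (chloro in place of hydrogen on an aromatic carbon). Within the data shown here, the only measured step with any bearing is large, at a 170-fold higher number from compound 1 to compound 2 (2.24 log units; beyond the scatter) with 1-methylpiperidin-4-yl in place of 2-chlorophenyl. Among the measured compounds shown here, that step exchanges a whole group, and no measured pair isolates the addition of chloro, so it gives only a loose guide to size. A much smaller change is therefore expected here, in the direction of a lower number in this assay and perhaps not far beyond the scatter. The expected step is a 2.5-fold lower number from compound 2 to compound 4 (0.41 log units; beyond the scatter) and is only an estimate. For compound 4 the estimated value is 25 ug/mL with an expected range from 7 ug/mL to 70 ug/mL ( an estimate, not a measurement ).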

Compound 4, solubility: 41 ug/mL
For compound 4 the middle estimate is 1.6-fold (0.21 log units) below the measured one; measured number inside the range.
By their numbers in this assay, from the lowest: compounds 1 and 3 (each within the scatter of the next); then compounds 4 and 2 (each within the scatter of the next).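

In this assay the step of a 1.6-fold lower number from compound 2 to compound 4 (0.19 log units; within the scatter) stays within the scatter, so at this place, on an aromatic carbon para to a large group, chloro in place of hydrogen gives no readable change. Among these compounds, the earlier step exchanged a whole group, whereas this pair is the first to isolate chloro alone, and phenyl and 4-chlorophenyl cannot be told apart here by this read-out. Nothing measured is available to explain this result.

As far as these compounds go, whether a different group at this same place, such as methoxy or a carboxylic acid, would give a step beyond the scatter remains open. So does whether chloro would give an equally small step on another aromatic ring of the molecule, or in a compound without the 1-methylpiperidin-4-yl group.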